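The compounds below may be only part of what the source reports. "The series", "measured", "known", "first", "only" and "open" are said of these compounds alone.

In a functional assay on M14 cells (Homo sapiens) for cytotoxicity (on this read-out higher numbers stand for weaker inhibition of growth and lower numbers for stronger inhibition of growth), compound 2 `CSc1ccc(C2=C(c3ccc(C)c(C)c3)C(=O)N3CCCC3C2)cc1` gives 800 nM, the lowest of the two numbers, and compound 3 `COc1ccc(C2=C(c3ccc(SC)cc3)CC3CCCN3C2=O)cc1OC` gives 5000 nM, a gap beyond the scatter. Compound 1 `COc1ccc(C2=C(c3cc(OC)c(OC)c(OC)c3)CC3CCCN3C2=O)cc1O` reads > 100000 nM, which is a limit of the assay and not a number. Compound 4 `CSc1ccc(C2=C(c3ccc(O)cc3)C(=O)N3CCCC3C2)cc1` carries 4-hydroxyphenyl in place of 3,4-dimethylphenyl on a double-bonded ring carbon. Going by the values given here, no measured pair isolates this change. A move towards a higher number is expected, and the estimated step is a 3.8-fold higher number from compound 2 to compound 4 (0.57 log units; beyond the scatter). That expectation leans on compound 3, which lacks the 3,4-dimethylphenyl group and gives 5000 nM. The estimate for compound 4 is 3000 nM, with an expected range of 800 nM to 15000 nM.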

Compound 4, concentration for 50% growth inhibition: > 100000 nM
Compound 4 was reported as a limit; the forecaster's own chance of this, stated with the estimate: 10%; at least 33-fold (1.52 log units) between middle value and limit.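

In this assay, going by these compounds alone, 4-hydroxyphenyl in place of 3,4-dimethylphenyl on a double-bonded ring carbon gives an at least 120-fold higher number from compound 2 to compound 4 (2.09 log units; beyond the scatter), the only step that isolates a change at this position. Compound 4 gives > 100000 nM, which is a limit of the assay and not a number. The step is therefore a lower bound on the size of this change: the limit of > 100000 nM in this assay, at which 2 of the 4 values shown sit.

Still open, going by these compounds, is whether the hydroxyl or the two methyl groups account for the step; a plain phenyl or a 4-methylphenyl here would separate the two. On these data alone, how an amine on this aromatic ring would read also remains open.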